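This account rests on a few compounds, and the source may have more. Where it says the series, first, only, none or still open, it means among the compounds named here.

Of the compounds shown here, three have been tested in a functional assay on B16 cells (Mus musculus) for inhibition; on this read-out higher numbers stand for weaker inhibition and lower numbers for stronger inhibition. Compound 1 `COc1ccc2oc(=O)cc(COC(=O)C=C(C)C)c2c1` gives > 10 ug/mL, which is a limit of the assay and not a number. Compound 2 `C/C=C/C(=O)OCc1cc(=O)oc2cc(OC)c(OC)cc12` gives > 10 ug/mL, which is likewise only a limit. Compound 2 therefore stands at the limit of > 10 ug/mL in this assay, at which 2 of the 3 values shown sit. Compound 3 `COc1cc2oc(=O)cc(COC(=O)/C=C/c3cc(OC)c(OC)c(OC)c3)c2cc1OC` is the only one of the three to return a number, 6.74 ug/mL.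

Compound 4 `COc1ccc(/C=C/C(=O)OCc2cc(=O)oc3cc(OC)c(OC)cc23)cc1O` has not yet been measured. It differs from compound 2 by a single change, 3-hydroxy-4-methoxyphenyl in place of methyl on a double-bonded chain carbon bound to a double-bonded chain carbon.

For the measured compounds named here, no measured step shows what such a change does in this assay. Going by the values given here, the expectation therefore leans on compound 3 at 6.74 ug/mL, the one measured number available. The expected at least 1.4-fold lower number from compound 2 to compound 4 (0.15 log units; that floor lies within the scatter) is a modest one towards stronger inhibition, and it may not clearly exceed the usual scatter. Compound 4 is estimated at 7 ug/mL, with an expected range of 3 ug/mL to 15 ug/mL.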

Compound 4, half-maximal inhibitory concentration: 3 ug/mL
Compound 4: middle estimate off by 2.3-fold (0.37 log units), on the high side; low and high end bracket the measured number.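

In this assay, placing 3-hydroxy-4-methoxyphenyl in place of methyl on a double-bonded chain carbon bound to a double-bonded chain carbon gives an at least 3.3-fold lower number from compound 2 to compound 4 (0.52 log units; beyond the scatter). For the compounds shown here, this is the first one-place change that can be read here, and it shows that this position accepts a substituted aromatic ring and that the change takes the read-out from a limit to a number. Compound 2 gives > 10 ug/mL, which is a limit of the assay and not a number, and the step is only a floor because compound 2 sits there: the limit of > 10 ug/mL in this assay, at which 2 of the 4 values shown sit.

From the compounds shown here alone, the full size of the step remains open, as does whether it comes from the aromatic ring itself or from its hydroxy and methoxy groups. An unsubstituted phenyl, or an amine on that ring, at the same place would be needed to separate these.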